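This account rests on a few compounds, and the source may have more. Where it says the series, first, only, none or still open, it means among the compounds named here.

In a functional assay on RPMI-8226 cells (Homo sapiens) for cytotoxicity, read by MTT assay, with a stated time of 48 h (on this read-out lower numbers stand for stronger inhibition and higher numbers for weaker inhibition), compound 1 `O=C(NN=C1C(Cl)=C(Cl)C(Cl)=C1Cl)c1ccccc1` gives 600 nM, the second highest of the three numbers shown. Compound 3 `Fc1cccc(NN=C2C(Cl)=C(Cl)C(Cl)=C2Cl)c1` gives 500 nM in this assay, and compound 2 `CC(=O)NN=C1C(Cl)=C(Cl)C(Cl)=C1Cl` gives 1000 nM; all three values lie within the scatter of one another. For the measured compounds named here, the only single-point step known, a 1.7-fold higher number from compound 1 to compound 2 (0.22 log units; within the scatter), shows that swapping the group on the carbonyl carbon leaves the number essentially unchanged. Compound 4 `O=C(c1ccccc1)N(N=C1C(Cl)=C(Cl)C(Cl)=C1Cl)C(=O)c1ccccc1` differs from compound 1 by benzoyl in place of hydrogen on an amide-type nitrogen. Going by the values given here, no measured pair touches the amide-type nitrogen itself, so no step bears on it directly; the one step that exists was within the scatter, and on that basis a step no larger than the scatter is expected, in either direction, as a 1.2-fold higher number from compound 1 to compound 4 (0.07 log units; within the scatter). Compound 4 is thus estimated at 700 nM, with a range from 250 nM to 2000 nM.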

Compound 4, half-maximal inhibitory concentration: 800 nM
Compound 4: middle estimate off by 1.1-fold (0.06 log units), on the low side; the range from low to high includes it.
By their numbers in this assay, from the lowest: compounds 3, 1, 4 and 2 (each within the scatter of the next).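

In this assay, for the compounds shown here, the amide-type nitrogen, which no earlier pair touched, takes benzoyl in place of hydrogen (a 1.3-fold higher number from compound 1 to compound 4 (0.12 log units; within the scatter)). The amide hydrogen is therefore not needed to keep the number within the scatter in this pair, and the added benzoyl, with its six-membered aromatic ring, is accommodated in this one comparison. No available evidence explains this result.

Benzoyl is the only replacement shown on this nitrogen, so it remains open how a methyl, a longer alkyl chain or a carboxylic acid-bearing chain would read there.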